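A few compounds are considered here, and "the series" means these few. Any claim that something is new, unique, unknown or untested is made for them only; others in the source may bear on it.

In a functional assay on KB cells (Homo sapiens) for cytotoxicity (a lower number here means that less compound is needed, a higher number that more compound is needed for the effect), compound 1 `COC1=C(C)C(=O)/C(=C(O)/C=C/c2c(C)cc(C)cc2C)C(=O)C1(C)C` gives 1.84 ug/mL, compound 2 `COC1=C(C)C(=O)/C(=C(O)/C=C/c2cccc3ccccc23)C(=O)C1(C)C` gives 1.3 ug/mL, and compound 3 `CCC1=C(OC)C(CC)(CC)C(=O)C(C(=O)/C=C/c2ccccc2)=C1O` gives 1.2 ug/mL. Compound 3 thus stands within the usual scatter of both other compounds. Compound 4 `CCC1=C(OC)C(CC)(CC)C(=O)C(C(=O)/C=C/c2ccc(CC)cc2)=C1O` departs from compound 3 in one place: ethyl in place of hydrogen on an aromatic carbon, para to a large group, which turns phenyl into 4-ethylphenyl. Among the measured compounds shown here, no measured pair shows this change on its own. The aromatic end already differs among the three measured compounds, and their values stay within the scatter, so no shift beyond it is expected in this assay. The expected step is a 1.1-fold lower number from compound 3 to compound 4 (0.04 log units; within the scatter). For compound 4 the estimated value is 1.1 ug/mL, with an expected range from 0.5 ug/mL to 2.5 ug/mL.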

Compound 4, concentration for half-maximal effect: 2.6 ug/mL
Estimate against measurement, compound 4: 2.4-fold (0.37 log units) below; the measured number lies above the stated range.
By their numbers in this assay, from the lowest: compounds 3, 2, 1 and 4 (each within the scatter of the next, the first and the last beyond it).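

In this assay, among the compounds shown here, placing ethyl on an aromatic carbon, para to a large group, gives a 2.2-fold higher number from compound 3 to compound 4 (0.34 log units; beyond the scatter), a single-place comparison that the earlier compounds did not offer. The position is thus not indifferent to this change, although the step is modest. Nothing available accounts for the shift.

As far as these compounds go, whether a methyl, a longer chain such as propyl, or an amine at this place would move the number in the same direction remains open. So does the effect of ethyl on any other carbon of this ring.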